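A Nitro Group Enters the Methoxyphenyl Side Chain

This account rests on a few compounds, and the source may have more. Where it says the series, first, only, none or still open, it means among the compounds named here.

Of the compounds shown here, three share one core and have been measured in an assay for inhibition of Thromboxane-A synthase (Homo sapiens), using microsomes; on this read-out higher numbers stand for weaker inhibition and lower numbers for stronger inhibition. Compound 1 `O=C(O)CC/C=C\CC1COC(c2ccccc2Cl)OC1c1cccnc1` gives 48 nM. Compound 2 `O=C(O)CC/C=C\CC1COC(c2ccc([N+](=O)[O-])cc2)OC1c1cccnc1` gives 39 nM. Compound 3 `COc1ccc(OC(C)(C)C2OCC(C/C=C\CCC(=O)O)C(c3cccnc3)O2)cc1` gives 41 nM. Compound 3 stands second highest of the three numbers, yet its gaps to both compound 2 and compound 1 lie within the scatter, so the three cannot be ranked against each other.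

Compound 4 `COc1ccc(OC(C)(C)C2OCC(C/C=C\CCC(=O)O)C(c3cccnc3)O2)c([N+](=O)[O-])c1` differs from compound 3 in one place: nitro in place of hydrogen on an aromatic carbon. Going by the values given here, the only measured step that touches a nitro group is a 1.2-fold lower number from compound 1 to compound 2 (0.09 log units; within the scatter), where a 4-nitrophenyl took the place of a 2-chlorophenyl on a saturated ring carbon and the number barely moved. That step sits on a different part of the molecule and swaps one substituted ring for another, so it bears only loosely on the present change. Among the compounds with values here, nothing among the measured compounds shows a nitro group entering an aromatic carbon that already carries a methoxy group.

Within the data shown here, with no step pointing in either direction, the expected change in this assay from compound 3 to compound 4 is a 1.0-fold lower number from compound 3 to compound 4 (0.01 log units; within the scatter), a move not beyond the scatter. Compound 4 is therefore estimated at 40 nM, between 15 nM and 110 nM.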

Compound 4, half-maximal inhibitory concentration: 37 nM
The estimate for compound 4 lay 1.1-fold (0.03 log units) above the measured number; measured number inside the range.
By their numbers in this assay, from the lowest: compounds 4, 2, 3 and 1 (each within the scatter of the next).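

In this assay, nitro in place of hydrogen on an aromatic carbon, ortho to a large group and meta to a methoxy group, gives a 1.1-fold lower number from compound 3 to compound 4 (0.04 log units; within the scatter), a step that lies within the scatter. Among the earlier compounds, a nitro group appeared only in the 4-nitrophenyl of compound 2, on a saturated ring carbon, whereas this pair isolates nitro as the single difference on the methoxyphenyl side chain: 4-methoxyphenyl in compound 3 and 4-methoxy-2-nitrophenyl in compound 4. The position therefore accepts these three extra heavy atoms without a difference that this read-out can separate from the scatter, and no evidence is available here to explain that result.

What the compounds shown leave open is how an amine, a nitrile or a chlorine atom in place of hydrogen on this same aromatic carbon would read in this assay. With only one substituent shown at this position, they also leave open whether the result extends to other groups or holds for nitro on the other carbons of this ring.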